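A Chloroaryl Swap in a Growth Inhibition Series

The source may hold more compounds than are shown below. What is called first, only, known or untested is meant among the compounds shown, and "the series" means these compounds.

In a functional assay on HepG2 cells (Homo sapiens) for antiproliferative activity, read by spectrophotometry, with a stated time of 2 days (on this read-out lower numbers stand for stronger inhibition of growth and higher numbers for weaker inhibition of growth), compound 1 (`CC(=O)N1CCN(c2ccc(Nc3ncc(C(F)(F)F)c(N4Cc5cccc(N(C)S(C)(=O)=O)c5C4)n3)cc2)CC1`) gives 1400 nM and compound 3 (`CN(c1cccc2c1CN(c1nc(Nc3cc(C(F)(F)F)cc(C(F)(F)F)c3)ncc1C(F)(F)F)C2)S(C)(=O)=O`) gives 10300 nM. Compound 2 (`COc1cc(Nc2ncc(C(F)(F)F)c(N3Cc4cccc(N(C)S(C)(=O)=O)c4C3)n2)c(OC)cc1Cl`) has the highest number of the three at 25600 nM, and both other numbers lie lower beyond the scatter. Compound 4 (`Cc1cc(Cl)ccc1Nc1ncc(C(F)(F)F)c(N2Cc3cccc(N(C)S(C)(=O)=O)c3C2)n1`) carries 4-chloro-2-methylphenyl in place of 4-chloro-2,5-dimethoxyphenyl on a nitrogen on an aromatic ring. Among the measured compounds shown here, no measured pair shows a change of this kind, so the expectation rests on the spread of the three values. With compound 2 at the top of that spread at 25600 nM, a moderate move to a lower number is expected in this assay. The expected step is a 2.8-fold lower number from compound 2 to compound 4 (0.45 log units; beyond the scatter). For compound 4 the estimated value is 9000 nM, with an expected range from 2500 nM to 25000 nM.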

Compound 4, concentration for 50% growth inhibition: 19600 nM
Beside the measured number, compound 4's estimate is 2.2-fold (0.34 log units) below it, within the range that was stated.
By their numbers in this assay, from the lowest: compound 1; then compounds 3, 4 and 2 (each within the scatter of the next, the first and the last beyond it).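

This first direct comparison at the nitrogen-bound aryl group in this assay gives a 1.3-fold lower number from compound 2 to compound 4 (0.12 log units; within the scatter) and so does not separate 4-chloro-2-methylphenyl from 4-chloro-2,5-dimethoxyphenyl. The hydrogen-bond acceptors on this group fall from 2 to 0 and the group loses heavy atoms, yet the change stays within the scatter. No supporting measurement bears on why this is so. The compounds shown leave open whether an amine or a carboxylic acid in place of the chlorine on this phenyl group would move the number beyond the scatter.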